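This account rests on a few compounds, and the source may have more. Where it says the series, first, only, none or still open, it means among the compounds named here.

Of the compounds shown here, three have been read so far in a functional assay on DU-145 cells (Homo sapiens) for inhibition, read by MTT assay, with stated times of 18 h and 4 h; on this read-out higher numbers stand for weaker inhibition and lower numbers for stronger inhibition. There compound 1 (`CCCCCCCCOP(=O)(O)OCCSC(=S)N1CCCC1`) gives 47100 nM and compound 3 (`CCCCCCCCCCOP(=O)(O)OCCSC(=S)N1CCN(C)CC1`) gives 82300 nM. These two numbers lie within the scatter of each other, so neither can be ranked over the other. For compound 2 (`CCCOP(=O)(O)OCCSC(=S)N1CCCCC1`) the result is a limit and not a number: > 100000 nM.

Compound 4 (`CCCCCCCCOP(=O)(O)OCCSC(=S)N1CCCCCC1`) has not yet been measured. It keeps the rest of compound 1 and changes one place, on a thiocarbonyl carbon: azepan-1-yl in place of pyrrolidin-1-yl on a thiocarbonyl carbon. The five-membered ring gives way to a seven-membered one, and the chain stays as it is.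

Going by the values given here, the measured compounds differ from one another in more than one place, so no single-change step is available to size this swap. Compound 1 at 47100 nM and compound 3 at 82300 nM carry different rings and different chains, yet remain within the scatter, and this gives no sign of a large ring effect. The estimated size of a 1.0-fold lower number from compound 1 to compound 4 (0.02 log units; within the scatter) is therefore expected to stay within the scatter, with no firm direction. In this assay the expected value for compound 4 is 45000 nM, with an estimated range from 20000 nM to 100000 nM.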

Compound 4, half-maximal inhibitory concentration: 59100 nM
Compound 4: the middle estimate sits 1.3-fold (0.12 log units) below what was measured, within the range that was stated.
By their numbers in this assay, from the lowest: compounds 1, 4 and 3 (each within the scatter of the next). At a limit, above all of these: compound 2.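

In this assay, going by these compounds alone, the swap of azepan-1-yl for pyrrolidin-1-yl on a thiocarbonyl carbon now has a size of its own, the only single-place step so far: a 1.3-fold higher number from compound 1 to compound 4 (0.10 log units; within the scatter). With the chain and the rest of the core of compound 1 held as they are, the seven-membered ring and the five-membered ring cannot be told apart on this read-out, so for this pair the place takes either ring without a readable change. The data at hand give no cause for this result and nothing that bears on it.

From the compounds shown here alone, whether the same holds for other groups in this place remains open, for example a morpholin-4-yl ring or an open-chain diethylamino group, each of which would need to be read against compound 1. Going by these compounds, it is also open whether the swap of pyrrolidin-1-yl for azepan-1-yl gives the same small step on another chain, such as a dodecyl chain, since only one chain has carried both rings here.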